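Chloro to Fluoro: A Single-Atom Change and Cytotoxicity

The source may report more compounds than this note shows. Statements on the series, on what has been measured and on what is new or still open speak of the compounds shown alone.

Compound 1 `O=C(Nc1ccc(C(F)(F)F)cc1)c1ccc(Cl)cc1O` — 1180 nM
Compound 2 `O=C(Nc1ccc(Br)c(Cl)c1)c1cc(F)ccc1O` — 1250 nM

In a functional assay on NALM-6 cells (Homo sapiens) for cytotoxicity, read by luminescence and CellTiter-Glo, with a stated time of 3 days (on this read-out lower numbers stand for stronger inhibition and higher numbers for weaker inhibition), compound 1 gives 1180 nM, the lower of the two numbers, a difference from compound 2 that sits within the scatter. Compound 3 `O=C(Nc1ccc(C(F)(F)F)cc1)c1ccc(F)cc1O` differs from compound 1 by fluoro in place of chloro on an aromatic carbon. Among the compounds with values here, no pair of measured compounds shows this exchange on its own. Compound 2, which also holds a fluoro, gives 1250 nM, close to compound 1. The step of a 1.5-fold higher number from compound 1 to compound 3 (0.18 log units; within the scatter) is therefore expected to stay within the scatter or to weaken only slightly. Compound 3 is estimated at 1800 nM, with a range from 700 nM to 4500 nM.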

Compound 3, half-maximal inhibitory concentration: 1530 nM
Compound 3: middle estimate off by 1.2-fold (0.07 log units), on the high side; the range from low to high includes it.
By their numbers in this assay, from the lowest: compounds 1, 2 and 3 (each within the scatter of the next).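

In this assay, placing fluoro instead of chloro on this aromatic carbon, meta to a hydroxy group and para to a large group, gives a 1.3-fold higher number from compound 1 to compound 3 (0.11 log units; within the scatter) on the core of compound 1. This single-atom exchange, which compound 2 could not isolate, shows that the two halogens cannot be told apart at this position. Nothing at hand explains this result. The compounds shown leave open whether this position would tolerate an amine, a carboxylic acid or a longer chain. They also leave open whether the same exchange would behave alike on another core.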